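Phenyl substitution across two linker lengths in one series

The compounds below may be only part of what the source reports. "The series", "measured", "known", "first", "only" and "open" are said of these compounds alone.

Measured so far, all in a functional assay on PC-12 cells (Rattus norvegicus) for cytotoxicity, read by MTT assay, with stated times of 3 h and 2 h, tested at 0.1 uM; on this read-out higher numbers stand for a stronger effect at the one concentration tested and lower numbers for a weaker effect:
compound 1 `O=C(CCCCC1CCSS1)NCc1cn(CCCOc2ccc3ccc(=O)oc3c2)nn1` gives 37.8%
compound 2 `O=C(CCCCC1CCSS1)NCc1cn(CCCOc2ccc3cc(-c4ccccc4)c(=O)oc3c2)nn1` gives 33.9%
compound 3 `O=C(CCCCC1CCSS1)NCc1cn(CCCCOc2ccc3ccc(=O)oc3c2)nn1` gives 40.5%

Among the measured compounds shown here, the one change made between measured compounds is phenyl in place of hydrogen on an aromatic carbon. It produced a number 3.9 percentage points lower from compound 1 to compound 2 (within the scatter), so on this read-out compound 1 and compound 2 cannot be told apart. Compound 3 differs from compound 1 in its core; the difference between the two cores is not broken down here. The values of compound 1 and compound 3 in this assay lie within the scatter of each other, so nothing is said of their order.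

Compound 4 `O=C(CCCCC1CCSS1)NCc1cn(CCCCOc2ccc3cc(-c4ccccc4)c(=O)oc3c2)nn1` is still to be measured in this assay. Relative to compound 3 it carries phenyl in place of hydrogen on an aromatic carbon, the same change as from compound 1 to compound 2, at a place described in the same words. For the measured compounds named here, the step from compound 3 to compound 4 is expected to be a number 3.9 percentage points lower from compound 3 to compound 4 (within the scatter), because the one earlier instance of this change gave a number 3.9 percentage points lower from compound 1 to compound 2 (within the scatter), a step within the scatter. Compound 4 is therefore estimated at 36.6%, expected to fall between 28% and 45%.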

Compound 4, a percentage reported as activity, at one concentration (the size of the read-out at that concentration, not a potency): 38.6%
Estimate against measurement, compound 4: 2 percentage points below, and the stated range covers the measured number.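

In this assay, phenyl in place of hydrogen on an aromatic carbon gives a number 1.9 percentage points lower from compound 3 to compound 4 (within the scatter), so neither instance of this change moves the read-out beyond the scatter. As far as this read-out can tell, the change behaves alike on the two cores: the same change on two cores in this assay, a number 3.9 percentage points lower (within the scatter) from compound 1 to compound 2 and a number 1.9 percentage points lower (within the scatter) from compound 3 to compound 4, 2 percentage points apart, within the scatter of two such steps

Among the compounds shown here, this agreement rests on two pairs tested at one concentration, and with both steps within the scatter, it shows only that no detectable step appears on either core, not that phenyl is without effect in other read-outs, at other concentrations or on other cores.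

The compounds shown leave open whether a group other than phenyl on this aromatic carbon, such as an amine or a carboxylic acid, would give a step beyond the scatter. They also leave open whether a longer chain in the linker, with or without the phenyl, would separate from the values seen so far.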